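Notes on a chloro for methoxy swap

A few compounds are considered here, and "the series" means these few. Any claim that something is new, unique, unknown or untested is made for them only; others in the source may bear on it.

Measured in a functional assay on HepG2 cells (Homo sapiens) for inhibition, read by MTT assay, with a stated time of 72 h; a higher number here means a weaker inhibitor, a lower number a stronger inhibitor:
- compound 1 `COc1ccc(/C=C/C(=O)c2c(OC)cc(O)c(CC=C(C)C)c2O)cc1` gives 32400 nM
- compound 2 `COc1ccc(/C=C/C(=O)c2c(O)cc(O)cc2OC)cc1` gives 18100 nM
- compound 3 `COc1ccc(/C=C/C(=O)c2c(O)cc(O)cc2OC)cc1OC` gives 18500 nM

Compound 2 stands level with compound 3 and within the scatter of compound 1. Compound 4 `COc1cc(O)cc(O)c1C(=O)/C=C/c1ccc(Cl)cc1` carries chloro in place of methoxy on an aromatic carbon, para to a large group (chloro in place of methoxy on an aromatic carbon). Among the compounds with values here, two measured steps bear on this. Hydrogen in place of 3-methylbut-2-en-1-yl gave a small step (a 1.8-fold lower number from compound 1 to compound 2 (0.25 log units; within the scatter)), and methoxy in place of hydrogen gave almost none (a 1.0-fold higher number from compound 2 to compound 3 (0.01 log units; within the scatter)). Neither step replaces this methoxy with chloro, so direct evidence is lacking. No step beyond the scatter is expected in this assay, and the estimated change is small (a 1.0-fold lower number from compound 2 to compound 4 (0.00 log units; within the scatter)). Compound 4 is estimated at (18000 nM), with an expected range (8000 nM to 40000 nM).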

Compound 4, half-maximal inhibitory concentration: 12200 nM
For compound 4 the middle estimate is 1.5-fold (0.17 log units) above the measured one, and the stated range covers the measured number.
By their numbers in this assay, from the lowest: compounds 4, 2, 3 and 1 (each within the scatter of the next, the first and the last beyond it).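

In this assay, replacing methoxy with chloro on this aromatic carbon, para to a large group, gives a 1.5-fold lower number from compound 2 to compound 4 (0.17 log units; within the scatter). Compound 4 is the first compound shown without methoxy at this position, and the change stays within the scatter even though the entering chloro has no hydrogen-bond acceptor. Nothing shown accounts for this outcome.

As far as these compounds go, whether an amine or a carboxylic acid at this position would also stay within the scatter remains open. Also open, from the compounds shown here alone, is whether chloro would behave the same way alongside the 3-methylbut-2-en-1-yl group of compound 1.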